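The source may hold more compounds than are shown below. What is called first, only, known or untested is meant among the compounds shown, and "the series" means these compounds.

Measured so far in an assay on isolated protein for inhibition of serine/threonine-protein kinase 10 (Homo sapiens), read by thermal shift assay, tested at 10 uM; a higher number here means that the compound stabilises the target more against heat, a lower number that the compound stabilises the target less:
compound 1 `Cc1cc(C)cc(NC(=O)Nc2cc(C(C)(C)C)nn2-c2ccccc2)c1` gives -0.3 degrees C.
compound 2 `CC(C)(C)c1cc(NC(=O)Nc2ccc(F)c(F)c2)n(-c2ccccc2)n1` gives 3.4 degrees C.

Going by the values given here, compound 2 holds the higher of the two numbers; its only neighbour is compound 1, and the step of a number 3.7 degrees C higher from compound 1 to compound 2 (beyond the scatter) lies beyond the scatter. Compound 3 `COc1cccc(NC(=O)Nc2cc(C(C)(C)C)nn2-c2ccccc2)c1` has not yet been measured in this assay. It differs from compound 2 by 3-methoxyphenyl in place of 3,4-difluorophenyl on an amide-type nitrogen. Among the compounds with values here, the one measured step that bears on this position is the exchange of one aryl group for another on the same amide-type nitrogen, which moved the shift by a modest amount, from compound 1 to compound 2. Compound 3 carries a third aryl group there, and nothing measured shows which way the read-out moves for it; a step of similar size, in either direction, is as plausible as none beyond the scatter. Compound 3 is therefore expected to fall between the two measured values, near 1.5 degrees C, with a range of -0.5 degrees C to 3.5 degrees C, which means an expected step of a number 1.9 degrees C lower from compound 2 to compound 3 (beyond the scatter).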

Compound 3, shift of the target's melting temperature: 3.7 degrees C
Compound 3: middle estimate off by 2.2 degrees C, on the low side, and the stated range ends below it.
By their numbers in this assay, from the lowest: compound 1; then compounds 2 and 3 (each within the scatter of the next).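

In this assay, 3-methoxyphenyl in place of 3,4-difluorophenyl on the amide-type nitrogen gives a number 0.30 degrees C higher from compound 2 to compound 3 (within the scatter) and so leaves the read-out unresolved between these two aryl groups, which shows that compound 3 reaches the level of compound 2 without any fluorine on this ring. Against 3,5-dimethylphenyl, the same 3-methoxyphenyl group gives a number 4.0 degrees C higher from compound 1 to compound 3 (beyond the scatter) and thus confirms with a second, independent aryl group that compound 1 is the one that stands apart in this set of three. Nothing at hand accounts for this outcome.

Three aryl groups are too few to show what sets 3,5-dimethylphenyl apart, and a plain phenyl, a 3-methylphenyl or a cyclohexyl group on the same nitrogen would help to separate the number of substituents from their kind. From the compounds shown here alone, the tert-butyl and phenyl groups of the shared core are the same in all three compounds, so it remains open how the read-out would respond to change there, for instance an amine or a carboxylic acid carried on that phenyl group.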